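Pyrimidine in Place of Chlorophenyl: Expected Solubility

The compounds below may be only part of what the source reports. "The series", "measured", "known", "first", "only" and "open" are said of these compounds alone.

Compound 3 `COc1ccc2nc(C)cc(OCC(=O)Nc3ccc(Cl)cc3)c2c1` was measured in a physicochemical assay for solubility, in phosphate buffer, measured as kinetic solubility, with a stated time of 1 h, at pH 7.4; on this read-out lower numbers stand for lower solubility and higher numbers for higher solubility; in this assay compound 3 gives 9000 nM. Among the compounds with values here, compound 1 `COc1ccc2nc(C)cc(OCC(=O)Nc3cccc(C)c3)c2c1` gives 193000 nM, so compound 3 carries the lowest of the two numbers, and the only step linking them is a 21-fold lower number from compound 1 to compound 3 (1.33 log units; beyond the scatter). Compound 2 `COc1ccc2nc(C)cc(OCC(=O)Nc3ccc(Br)c(C)c3)c2c1` gives < 1000 nM, which is a limit of this assay and not a number. The step of an at least 190-fold lower number from compound 1 to compound 2 (2.28 log units; beyond the scatter) is therefore known only as a bound, as is an at least 9.0-fold higher number from compound 2 to compound 3 (0.95 log units; beyond the scatter); one of the three values sits at the limit of < 1000 nM in this assay, at which 1 of the 3 values shown sits.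

Compound 4 `COc1ccc2nc(C)cc(OCC(=O)Nc3ccncn3)c2c1` differs from compound 3 in one place: pyrimidin-4-yl in place of 4-chlorophenyl on an amide-type nitrogen. The two measured steps that bear on it, a 21-fold lower number from compound 1 to compound 3 (1.33 log units; beyond the scatter) and an at least 190-fold lower number from compound 1 to compound 2 (2.28 log units; beyond the scatter), both show that bringing a halogen onto the aryl ring lowered this read-out sharply; here the chlorine-bearing ring leaves altogether. Within the data shown here, no measured step covers a ring with two nitrogens. The expected change is a 6.7-fold higher number from compound 3 to compound 4 (0.82 log units; beyond the scatter), a rise beyond the scatter. Compound 4 is estimated at 60000 nM, with a range from 15000 nM to 250000 nM.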

Compound 4, solubility: 27500 nM
Beside the measured number, compound 4's estimate is 2.2-fold (0.34 log units) above it; low and high end bracket the measured number.
By their numbers in this assay, from the lowest: compound 3; then compound 4; then compound 1. At a limit, below all of these: compound 2.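

In this assay, a 3.1-fold higher number from compound 3 to compound 4 (0.49 log units; beyond the scatter) shows that pyrimidin-4-yl on the amide-type nitrogen reads above the chlorine-bearing ring, though by less than the opening estimate suggested. The same swap made on the 3-methylphenyl ring gives a 7.0-fold lower number from compound 1 to compound 4 (0.85 log units; beyond the scatter) and so goes the other way, which places compound 4 in the middle and shows that the direction of the change depends on which ring leaves. Compound 2 sits at a limit of the assay and not at a number, so an at least 27-fold higher number from compound 2 to compound 4 (1.43 log units; beyond the scatter) is known only as a bound: the limit of < 1000 nM in this assay, at which 1 of the 4 values shown sits.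

The compounds shown leave open how a pyridinyl ring or a plain phenyl ring would read at this position. They also leave open what an amine or a carboxylic acid on the pyrimidine ring would do to this number.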